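Sulfonamide series: trifluoromethyl replaces ethyl, third compound pending

The source may hold more compounds than are shown below. What is called first, only, known or untested is meant among the compounds shown, and "the series" means these compounds.

Compound 1 `C=Cc1ccc(S(=O)(=O)Nc2ccc3oc(-c4ccccc4)nc3c2)cc1` and compound 2 `CCc1ccc(S(=O)(=O)Nc2ccc3oc(-c4ccccc4)nc3c2)cc1` share one core. In an assay on isolated protein for inhibition of malate dehydrogenase, mitochondrial (Sus scrofa), with stated times of 45 min and 30 min (a higher number here means a weaker inhibitor, a lower number a stronger inhibitor), compound 1 sits at the assay limit, > 63000 nM. In this assay compound 2 also sits at the limit, > 63000 nM. The step that the two limits leave unreadable from compound 1 to compound 2 is therefore unreadable; both values rest on (the limit of > 63000 nM in this assay, at which 2 of the 2 values shown sit). Compound 3 `O=S(=O)(Nc1ccc2oc(-c3ccccc3)nc2c1)c1ccc(C(F)(F)F)cc1` differs from compound 2 by trifluoromethyl in place of ethyl on an aromatic carbon. Among the measured compounds shown here, only that unreadable step bears on this change, so in this assay no movement beyond the scatter is expected. The expected step is a step that the limit leaves unreadable from compound 2 to compound 3. Compound 3 is expected to give about 100000 nM, between 40000 nM and 300000 nM, most likely again only as a limit.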

Compound 3, half-maximal inhibitory concentration: > 63000 nM
Compound 3: no number, only a limit; the forecaster's own chance of this, stated with the estimate: 85%; the middle value lies beyond the limit too.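

Among the compounds shown here, no step among compound 1, compound 2 and compound 3 can be read in this assay, since all three values are limits: the limit of > 63000 nM in this assay, at which 3 of the 3 values shown sit.

From the compounds shown here alone, how vinyl, ethyl and trifluoromethyl on the shared core rank against one another remains open.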